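This account rests on a few compounds, and the source may have more. Where it says the series, first, only, none or still open, it means among the compounds named here.

Measured so far:
- compound 1, `CCNC(=O)C1CCN(c2nc(N)c3cc(OC)c(OC)cc3n2)CC1`: 1.64 nM
- compound 2, `COc1cc2nc(N3CCC(C(=O)NCCO)CC3)nc(N)c2cc1OC`: 1.73 nM
- compound 3, `COc1cc2nc(N3CCC(C(=O)Nc4ccccc4)CC3)nc(N)c2cc1OC`: 0.47 nM

All three were tested in an assay on isolated protein for displacement of a labelled ligand from Adrenergic receptor alpha-1 (Rattus norvegicus); on this read-out higher numbers stand for weaker inhibition and lower numbers for stronger inhibition. Compound 1 gives the second highest of the three numbers; its nearest neighbour is compound 2, the gap being a 1.1-fold higher number from compound 1 to compound 2 (0.02 log units; within the scatter), while compound 3 lies furthest away, at a 3.5-fold lower number from compound 1 to compound 3 (0.54 log units; beyond the scatter). The unmeasured compound 4, `CCCCNC(=O)CC1CCN(c2nc(N)c3cc(OC)c(OC)cc3n2)CC1`, differs from compound 1 by (butylcarbamoyl)methyl in place of ethylcarbamoyl on a saturated ring carbon.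

Among the compounds with values here, two measured steps touch the group on the amide-type nitrogen: a 3.5-fold lower number from compound 1 to compound 3 (0.54 log units; beyond the scatter) and a 3.7-fold lower number from compound 2 to compound 3 (0.57 log units; beyond the scatter), both modest and both toward a lower number when the group on that nitrogen grows. Within the data shown here, the step to compound 4 also enlarges the group on the amide-type nitrogen, from ethyl to butyl, but at the same time inserts a methyl between the ring carbon and the carbonyl, a change for which no measured step exists. The expectation is therefore a small lowering in this assay, weaker than the phenyl steps: compound 4 is estimated at 1 nM, within 0.4 nM to 2.5 nM, which as a step means an expected 1.6-fold lower number from compound 1 to compound 4 (0.21 log units; within the scatter).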

Compound 4, inhibition constant: 1.4 nM
The estimate for compound 4 lay 1.4-fold (0.15 log units) below the measured number; the measured number falls inside the stated range.
By their numbers in this assay, from the lowest: compound 3; then compounds 4, 1 and 2 (each within the scatter of the next).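

In this assay, the larger (butylcarbamoyl)methyl group on the saturated ring carbon is tolerated: the result matches ethylcarbamoyl (a 1.2-fold lower number from compound 1 to compound 4 (0.07 log units; within the scatter)) and (2-hydroxyethyl)carbamoyl (a 1.2-fold lower number from compound 2 to compound 4 (0.09 log units; within the scatter)). Phenylcarbamoyl alone stands apart (a 3.0-fold higher number from compound 3 to compound 4 (0.47 log units; beyond the scatter)), and compound 4 goes against any reading that a larger group here simply gives a lower number. Nothing in the data explains why the phenylcarbamoyl compound stands apart.

On these data alone, the butyl chain and the added carbon arrive together in compound 4, so how much of the result belongs to each remains open. Also open, as far as these compounds go, is how a butylcarbamoyl group attached directly to the ring carbon, a (phenylcarbamoyl)methyl group or a carboxylic acid at this place would read.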